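Aryl ether in place of isopropyl on the azabicyclic pyridine series

The source may hold more compounds than are shown below. What is called first, only, known or untested is meant among the compounds shown, and "the series" means these compounds.

Measured compounds in this set:
Compound 1 `CC(C)Oc1cncc(C2=CC3CNCC(C2)C3)c1`: 0.26 nM
Compound 2 `C1=C(c2cccnc2)CC2CNCC1C2`: 0.2 nM
Compound 3 `CC(C)Oc1cncc(C2=CC3CC(C2)CN(C)C3)c1`: 2.2 nM

In an in vitro assay on SH-EP1 cells for displacement of a labelled ligand from Neuronal acetylcholine receptor; alpha4/beta2 (Homo sapiens) (a lower number here means a stronger inhibitor, a higher number a weaker inhibitor), compound 1 gives 0.26 nM, the second highest of the three numbers. Its nearest neighbour is compound 2, which in this assay gives 0.2 nM; the step of a 1.3-fold lower number from compound 1 to compound 2 (0.11 log units; within the scatter) replaces the isopropoxy on an aromatic carbon with hydrogen and stays within the scatter. The furthest is compound 3, which in this assay gives 2.2 nM; the step of an 8.5-fold higher number from compound 1 to compound 3 (0.93 log units; beyond the scatter) puts methyl in place of hydrogen on the ring amine nitrogen and is a modest loss.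

Compound 4 `COc1cccc(Oc2cncc(C3=CC4CNCC(C3)C4)c2)c1` has not yet been measured. Its difference from compound 1 is 3-methoxyphenyl in place of isopropyl on an oxygen on an aromatic ring. For the measured compounds named here, of the measured steps, only the step from compound 1 to compound 2 bears on this position: it shows that the isopropoxy itself can be removed without any change beyond the scatter, so the oxygen substituent is not carrying the binding. Going by the values given here, no measured step tests a larger group at this oxygen, and the 3-methoxyphenyl is much larger than what it replaces. A small step, possibly upward, is therefore expected, a 2.7-fold higher number from compound 1 to compound 4 (0.43 log units; beyond the scatter). Compound 4 is estimated at 0.7 nM, within 0.2 nM to 3 nM.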

Compound 4, inhibition constant: 0.9 nM
For compound 4 the middle estimate is 1.3-fold (0.11 log units) below the measured one, within the range that was stated.
By their numbers in this assay, from the lowest: compounds 2 and 1 (each within the scatter of the next); then compound 4; then compound 3.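

In this assay, for the compounds shown here, the step of a 3.5-fold higher number from compound 1 to compound 4 (0.54 log units; beyond the scatter) gives the first reading of a group larger than isopropyl on this oxygen, and the change costs something beyond the scatter, whereas the removal of isopropoxy in a 1.3-fold lower number from compound 1 to compound 2 (0.11 log units; within the scatter) did not. The position therefore responds to what is attached to the oxygen, but it still accepts an added six-membered aromatic ring with only a modest loss, and compound 4 stays at 0.9 nM. No available measurement explains the loss, and it cannot be divided between the aromatic ring and its methoxy.

The compounds shown leave open whether plain phenyl on this oxygen would match compound 4 or compound 1, and whether a longer chain such as n-butyl, or a chain ending in an amine or a carboxylic acid, would be tolerated as well. Also open, going by these compounds, is whether methyl on the ring amine nitrogen, which gives an 8.5-fold higher number from compound 1 to compound 3 (0.93 log units; beyond the scatter) in the isopropyl ether, would cost a similar amount in the 3-methoxyphenyl ether.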